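Replacing the (propanoylamino)methyl arm with a carbamoyl group

A few compounds are considered here, and "the series" means these few. Any claim that something is new, unique, unknown or untested is made for them only; others in the source may bear on it.

Compound 2 `CCNC(=O)c1noc(-c2cc(C(C)C)c(O)cc2O)c1-c1cc(CNC(=O)CC)no1` was assessed in a functional assay on HCT-116 cells (Homo sapiens) for inhibition; on this read-out lower numbers stand for stronger inhibition and higher numbers for weaker inhibition. In that assay compound 2 gives 78 nM; compound 1 `CCNC(=O)c1noc(-c2cc(C(C)C)c(O)cc2O)c1-c1cc(CNC(C)C)no1` gives 109 nM, and the step of a 1.4-fold lower number from compound 1 to compound 2 (0.15 log units; within the scatter) lies within the scatter, so the two compounds cannot be told apart on these numbers. Compound 3 `CCNC(=O)c1noc(-c2cc(C(C)C)c(O)cc2O)c1-c1cc(C(=O)OCC)no1` gives "not determined" (no result reported) and adds nothing to the comparison. Compound 4 `CCNC(=O)c1noc(-c2cc(C(C)C)c(O)cc2O)c1-c1cc(C(N)=O)no1` differs from compound 2 by carbamoyl in place of (propanoylamino)methyl on an aromatic carbon. For the measured compounds named here, the only measured step, from compound 1 to compound 2, exchanges one substituent on the amine nitrogen for another and stays within the scatter; it does not remove the whole (propanoylamino)methyl group, so no measured step bears directly on the change to compound 4. Going by the values given here, with no step showing a large effect at this position, compound 4 is expected to land close to compound 2, the step of a 1.3-fold higher number from compound 2 to compound 4 (0.11 log units; within the scatter) being expected to stay within or near the scatter. Compound 4 is therefore estimated at 100 nM, with a range from 40 nM to 300 nM.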

Compound 4, half-maximal inhibitory concentration: 79 nM
Compound 4: the middle estimate sits 1.3-fold (0.10 log units) above what was measured; measured number inside the range.
By their numbers in this assay, from the lowest: compounds 2, 4 and 1 (each within the scatter of the next).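

In this assay, compound 4 carries a much smaller arm on this aromatic carbon than compound 2. The 6 heavy atoms of (propanoylamino)methyl give way to the 3 heavy atoms of carbamoyl, and the numbers show no readable shift (a 1.0-fold higher number from compound 2 to compound 4 (0.01 log units; within the scatter)). The same holds when carbamoyl stands in place of (isopropylamino)methyl (a 1.4-fold lower number from compound 1 to compound 4 (0.14 log units; within the scatter)). Compound 1, compound 2 and compound 4 thus carry three different groups at this carbon, next to the ring nitrogen, and cannot be told apart on their numbers, and nothing available explains this result.

The compounds shown leave open whether a carboxylic acid, a primary aminomethyl group or a longer chain at this carbon would also stay within the scatter of these numbers. They also leave open what a bare hydrogen or a methyl group here would give, with no arm at all.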